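The source may report more compounds than this note shows. Statements on the series, on what has been measured and on what is new or still open speak of the compounds shown alone.

Measured so far:

Compound 1 `CCC(c1ccc(-c2cscc2C)cc1)n1ccnc1`, in an assay for inhibition of steroid 17-alpha-hydroxylase/17,20 lyase (Homo sapiens), using NADPH, tested at 0.2 uM (a lower number here means a weaker effect, a higher number a stronger effect of the compound at the concentration tested), compound 1 gives 27%.
Compound 2 `Cc1cscc1-c1ccc(Cn2ccnc2)cc1`, in this assay compound 2 gives 0%.
Compound 3 `CCC(c1cc(-c2ccc(F)c(F)c2)cs1)n1ccnc1`, in this assay compound 3 gives 17%.

Compound 2 differs from compound 1 in one place: hydrogen in place of ethyl on a saturated chain carbon bound to an aromatic carbon and an aromatic nitrogen. That change produced a number 27 percentage points lower from compound 1 to compound 2 (beyond the scatter), and it is repeated from compound 3 to compound 4 `Fc1ccc(-c2csc(Cn3ccnc3)c2)cc1F`: hydrogen in place of ethyl on a saturated chain carbon bound to an aromatic carbon and an aromatic nitrogen. Compound 3 and compound 4 share a core that is not the core of compound 1; the difference between the two cores is not broken down here. The values of compound 1 and compound 3 lie within the scatter of each other, so the two cores give no separate signal to go on. With the same change being made from compound 3, the account expects a step of a number 14 percentage points lower from compound 3 to compound 4 (beyond the scatter), resting on the drop that compound 1 showed when it became compound 2, a number 27 percentage points lower from compound 1 to compound 2 (beyond the scatter). Compound 4 is therefore expected to give about 3%, in a range from 0% to 15%.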

Compound 4, a percentage reported as inhibition, at one concentration (the size of the read-out at that concentration, not a potency): 7%
Compound 4: middle estimate off by 4 percentage points, on the low side, within the range that was stated.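

In this assay hydrogen in place of ethyl gives a number 10 percentage points lower from compound 3 to compound 4 (within the scatter) and so no clear loss on this core, and the size of the step does not carry over from the core of compound 1: the same change on two cores in this assay, a number 27 percentage points lower (beyond the scatter) from compound 1 to compound 2 and a number 10 percentage points lower (within the scatter) from compound 3 to compound 4, 17 percentage points apart, beyond the scatter of two such steps. A step read on one core therefore cannot simply be transferred to the other in this series. This does not show which part of the cores sets the difference, and two cores give no general rule.

The compounds shown leave open how a methyl or a longer chain such as propyl would read in place of the ethyl on either core. They also leave open what an amine on that chain would do.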